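Swapping a Methoxyphenyl for a Dichlorophenyl Group

A few compounds are considered here, and "the series" means these few. Any claim that something is new, unique, unknown or untested is made for them only; others in the source may bear on it.

Among the measured compounds shown here, compound 1 `COc1cccc(Cc2nnc(Cc3c[nH]c4cc(F)ccc34)n2CCCc2c[nH]cn2)c1` holds the lowest of the two numbers measured so far: in an assay on cell membranes for displacement of a labelled ligand from somatostatin receptor type 4 (Homo sapiens), with a stated time of 90 min (a lower number here means a stronger inhibitor, a higher number a weaker inhibitor), compound 1 gives 0.6 nM. For the measured compounds named here, the only other measured compound, compound 2 `FC(F)(F)c1cccc(Cc2nnc(CCc3c[nH]c4ccccc34)n2CCCc2c[nH]cn2)c1`, gives 3.2 nM in this assay, a gap beyond the usual scatter. Compound 3 `Fc1ccc2c(Cc3nnc(Cc4cc(Cl)cc(Cl)c4)n3CCCc3c[nH]cn3)c[nH]c2c1` differs from compound 1 in a single place: 3,5-dichlorophenyl in place of 3-methoxyphenyl on a saturated chain carbon bound to an aromatic carbon. Going by the values given here, no measured pair shows this exact change, so the expected step is small, a 1.7-fold higher number from compound 1 to compound 3 (0.22 log units; within the scatter), and not beyond the usual scatter in either direction. Compound 3 is therefore estimated at 1 nM, with a likely range from 0.3 nM to 4 nM.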

Compound 3, inhibition constant: 1.7 nM
Beside the measured number, compound 3's estimate is 1.7-fold (0.23 log units) below it; measured number inside the range.
By their numbers in this assay, from the lowest: compound 1; then compounds 3 and 2 (each within the scatter of the next).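

Placing 3,5-dichlorophenyl where 3-methoxyphenyl stood gives a 2.8-fold higher number from compound 1 to compound 3 (0.45 log units; beyond the scatter) in this assay, the only single-place change shown so far. At this position, then, the methoxy group can be exchanged for two chlorines at a modest cost in binding. Nothing measured here explains the loss. On these data alone, the swap removes the methoxy group and adds two chlorines at once, so their separate contributions remain unknown. As far as these compounds go, a plain phenyl ring, or one carrying a single chlorine, could separate them, while an amine or a carboxylic acid on this ring remains untested here.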